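Piperidin-1-yl to Isopropoxy on a Carbonyl Carbon

The compounds below may be only part of what the source reports. "The series", "measured", "known", "first", "only" and "open" are said of these compounds alone.

Measured compounds and their values:
compound 1 `c1ccc(-c2ccc(Cn3cncc3CNc3cccc(-c4ccccc4)c3)cc2)cc1`: 10000 nM
compound 2 `c1ccc(-c2ccc(Cn3cncc3CNc3ccc(-c4onc5ccccc45)c(-c4ccccc4)c3)cc2)cc1`: > 10000 nM
compound 3 `O=C(c1ccc(NCc2cncn2Cc2ccc(-c3ccccc3)cc2)cc1-c1ccccc1)N1CCCCC1`: > 1000 nM

In a toxicity assay on NIH3T3 cells (Mus musculus) for cytotoxicity, read by resazurin assay (on this read-out lower numbers stand for an effect already at smaller amounts and higher numbers for an effect only at larger amounts of compound), compound 1 gives 10000 nM, a number. For compound 2 the value > 10000 nM is a limit of this assay, not a number. For compound 3 the value > 1000 nM is likewise a limit. Compound 3 therefore stands only at a limit, and the steps towards it cannot be sized: a step that the limit leaves unreadable from compound 1 to compound 3 and a step that the two limits leave unreadable from compound 2 to compound 3, while a number no lower from compound 1 to compound 2 (the limit leaves the size open). The limits themselves are the limit of > 1000 nM in this assay, at which 1 of the 3 values shown sits, and (the limit of > 10000 nM in this assay, at which 1 of the 3 values shown sits).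

Compound 4 `CC(C)OC(=O)c1ccc(NCc2cncn2Cc2ccc(-c3ccccc3)cc2)cc1-c1ccccc1` differs from compound 3 in one place: isopropoxy in place of piperidin-1-yl on a carbonyl carbon. Among the measured compounds shown here, no measured step matches this change, and the steps that touch compound 3 are unreadable, so no direction beyond the scatter can be expected. Compound 4 is therefore expected near the number of compound 1, at 10000 nM, within 3000 nM to 30000 nM. This expectation corresponds to a step that the limit leaves unreadable from compound 3 to compound 4, most likely reported again as a limit.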

Compound 4, half-maximal effective concentration: > 10000 nM
Compound 4 was reported as a limit (the forecaster's own chance of this, stated with the estimate: 60%); the middle value lies on the limit itself.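

In this assay compound 4 gives > 10000 nM, which is a limit and not a number. Among the compounds shown here, the one step that can be read, and only for its direction, is a number no lower from compound 1 to compound 4 (the limit leaves the size open), while the steps to compound 4 from compound 3 and from compound 2 cannot be read. Compound 4 thus stands at the same limit as compound 2: the limit of > 10000 nM in this assay, at which 2 of the 4 values shown sit.

Going by these compounds, the size of any difference between piperidin-1-yl and isopropoxy on this carbonyl carbon stays open, and so does the distance of compound 4 from compound 1. Also open, on these data alone, is how the compound would read with a dimethylamino group on the carbonyl carbon, or with a hydroxy group there, which would give a carboxylic acid.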